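One Fluorine, Two Positions: Expecting Little Change

The compounds below may be only part of what the source reports. "The series", "measured", "known", "first", "only" and "open" are said of these compounds alone.

Measured compounds:
Compound 1 `COc1cc2ncnc(NNC(=S)NC(=O)c3ccc(F)cc3)c2cc1OC` — 25800 nM
Compound 2 `O=C(NC(=S)NNc1ncnc2ccccc12)c1cccc(Cl)c1` — 3540 nM

Both compounds were tested in a functional assay on MCF7 cells (Homo sapiens) for cytotoxicity, read by MTT assay, with a stated time of 72 h; on this read-out higher numbers stand for weaker inhibition and lower numbers for stronger inhibition. Compound 1 gives 25800 nM, the higher of the two numbers, meaning the weaker inhibition of the pair. Compound 2 gives 3540 nM, and the gap between these two values lies beyond the usual scatter, so compound 2 is the stronger inhibitor here. Compound 2 differs from compound 1 in more than one place, so no single structural change can be tied to that gap.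

Compound 3 `COc1cc2ncnc(NNC(=S)NC(=O)c3ccccc3F)c2cc1OC` has not yet been measured. It keeps every atom of compound 1 and differs only in how they are joined: 2-fluorophenyl in place of 4-fluorophenyl on a carbonyl carbon. Among the measured compounds shown here, no single-change step between measured compounds exists to calibrate such a move, so the expectation rests on the change itself being small. The step from compound 1 to compound 3 is expected to be a 1.2-fold lower number from compound 1 to compound 3 (0.07 log units; within the scatter), that is, no change beyond the scatter in either direction. Compound 3 is therefore expected to give about 22000 nM, within a range of 7000 nM to 70000 nM.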

Compound 3, half-maximal inhibitory concentration: 8500 nM
Estimate against measurement, compound 3: 2.6-fold (0.41 log units) above, and the stated range covers the measured number.
By their numbers in this assay, from the lowest: compound 2; then compound 3; then compound 1.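

In this assay the fluorine changes place while every atom stays, giving a 3.0-fold lower number from compound 1 to compound 3 (0.48 log units; beyond the scatter). Among the compounds shown here, this is the first comparison here in which only one thing differs, and it shows that the stronger inhibition goes with 2-fluorophenyl rather than 4-fluorophenyl on this carbonyl carbon, even though the two groups have the same atoms and the same counts. The step is modest in size, and no measurement here gives a reason for it.

The compounds shown leave open whether the fluorine itself matters, since no compound carries a methyl group, a methoxy group or an amine in its place on that ring. Compound 2 differs from compound 3 in more than one place, so that pair cannot show whether the same move would give a similar step on the core of compound 2.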